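This account rests on a few compounds, and the source may have more. Where it says the series, first, only, none or still open, it means among the compounds named here.

Working notes on the series. Compound 1 `Cc1cc(C)nc(SCc2cc(=O)c3cc(Cl)ccc3o2)n1` and compound 2 `O=c1cc(CSc2nc3ccccc3s2)oc2ccc(Cl)cc12` differ in more than one place; the difference between the two cores is not broken down here. In a functional assay on HEp-2 cells (Homo sapiens) for cytotoxicity, read by MTT assay, with a stated time of 72 h (a higher number here means a weaker inhibitor, a lower number a stronger inhibitor), compound 1 gives > 25000 nM, which is a limit of the assay and not a number. In this assay compound 2 gives > 25000 nM, also a limit. Compound 3 `Cc1ccc2oc(CSc3nc(C)cc(C)n3)cc(=O)c2c1` differs from compound 1 by methyl in place of chloro on an aromatic carbon. In this assay compound 3 gives > 25000 nM, once more a limit. The step that the two limits leave unreadable from compound 1 to compound 3 is therefore unreadable, since (the limit of > 25000 nM in this assay, at which 3 of the 3 values shown sit). Compound 4 `Cc1ccc2oc(CSc3nc4ccccc4s3)cc(=O)c2c1` differs from compound 2 by the same change, (methyl in place of chloro on an aromatic carbon). The step that the limit leaves unreadable from compound 2 to compound 4 is expected to be small because a step that the two limits leave unreadable from compound 1 to compound 3 gave nothing readable in either direction. Compound 4 is accordingly expected at about 35000 nM, with a range from 15000 nM to 150000 nM, and most probably reported again only as a limit.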

Compound 4, half-maximal inhibitory concentration: > 25000 nM
Compound 4 ended at the assay's limit; the forecaster's own chance of this, stated with the estimate: 85%; the middle value lies beyond the limit too.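

No step can be read from compound 2 to compound 4, since both values are limits and not numbers: the limit of > 25000 nM in this assay, at which 4 of the 4 values shown sit.

The compounds shown leave open how chloro and methyl compare in this assay, and what cytotoxic potency, if any, this series has.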